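Removing the Indole N-Methyl in a Chalcone Series

The source may report more compounds than this note shows. Statements on the series, on what has been measured and on what is new or still open speak of the compounds shown alone.

Compound 1 `COc1ccc2c(/C=C/C(=O)c3cc(OC)c(OC)c([N+](=O)[O-])c3)c[nH]c2c1` and compound 3 `COc1ccc2c(/C=C/C(=O)c3cc(OC)c(OC)c([N+](=O)[O-])c3)cn(C)c2c1` share one core, while compound 2 `COc1cc(C(=O)/C=C/c2cn(C)c3ccccc23)cc(N)c1OC` and compound 4 `COc1cc(C(=O)/C=C/c2c[nH]c3ccccc23)cc(N)c1OC` share another; the difference between the two cores is not broken down here. In a functional assay on A549 cells (Homo sapiens) for antiproliferative activity, read by MTT assay, with a stated time of 48 h (a lower number here means a stronger inhibitor, a higher number a weaker inhibitor), compound 1 gives 331 nM, compound 3 gives 1020 nM, and compound 2 gives 498 nM. Within the first core the change hydrogen in place of methyl on an aromatic nitrogen brought a 3.1-fold lower number from compound 3 to compound 1 (0.49 log units; beyond the scatter). Compound 4 carries the same change on the second core, (hydrogen in place of methyl on an aromatic nitrogen), with the place described in identical words. Within the data shown here, by the same change on compound 2, compound 4 is expected to show a 2.6-fold lower number from compound 2 to compound 4 (0.42 log units; beyond the scatter) because the earlier step gave a 3.1-fold lower number from compound 3 to compound 1 (0.49 log units; beyond the scatter), though only one prior instance supports this. Compound 4 is therefore estimated at 190 nM, between 90 nM and 400 nM.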

Compound 4, half-maximal inhibitory concentration: 342 nM
The estimate for compound 4 lay 1.8-fold (0.26 log units) below the measured number, and the stated range covers the measured number.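

On the core of compound 2, hydrogen in place of methyl on an aromatic nitrogen gave a 1.5-fold lower number from compound 2 to compound 4 (0.16 log units; within the scatter), a step that on its own cannot be told apart from repeat measurement. Set beside the step on the first core, it does not differ from it in this assay: the same change on two cores in this assay, a 3.1-fold lower number (0.49 log units; beyond the scatter) from compound 3 to compound 1 and a 1.5-fold lower number (0.16 log units; within the scatter) from compound 2 to compound 4, 2.1-fold (0.33 log units) apart, within the scatter of two such steps. Among these compounds, the two cores thus give no sign that the change behaves differently from one to the other, but this does not show that it carries over at a fixed size: only two pairs stand behind it, and only one of them lies beyond the scatter.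

The compounds shown leave open what an ethyl group, a longer chain or an acetyl group on that nitrogen would do. They also leave open whether the step would hold on a third core.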